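The compounds below may be only part of what the source reports. "The series", "measured", "known", "first", "only" and "open" are said of these compounds alone.

Measured so far in a physicochemical assay for metabolic stability, read by HPLC and mass spectrometry, in phosphate buffer, at 37 degrees C, at pH 7.4; on this read-out higher numbers stand for a longer-lived compound and lower numbers for a shorter-lived compound:
- Compound 1 `CC(C)(O/N=C(\C(=O)N[C@@H]1C(=O)N(S(=O)(=O)O)[C@@H]1CN1CCCC1=O)c1csc(N)n1)C(=O)O`: > 1000 h (a limit)
- Compound 2 `CC(C)(O/N=C(\C(=O)N[C@@H]1C(=O)N(S(=O)(=O)O)[C@@H]1Cn1cnnc1)c1csc(N)n1)C(=O)O`: 113 h

The value of compound 1 is a limit of the assay and not a number. Going by the values given here, that leaves compound 2 with the only true number so far, at 113 h.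

Compound 3 `CC(C)(O/N=C(\C(=O)N[C@@H]1C(=O)N(S(=O)(=O)O)[C@@H]1CN1C[C@@H](CN)OC1=O)c1csc(N)n1)C(=O)O` changes compound 2 on a saturated chain carbon bound to a saturated ring carbon: a group of 8 heavy atoms (4 carbon, 2 nitrogen, 2 oxygen; one five-membered non-aromatic ring with 2 hetero atoms) in place of a group of 5 heavy atoms (2 carbon, 3 nitrogen; one five-membered aromatic ring with 3 hetero atoms), on a saturated chain carbon bound to a saturated ring carbon. The aromatic ring leaves and a five-membered non-aromatic ring enters.

Among the compounds with values here, only one measured step bears on this: an at least 8.8-fold lower number from compound 1 to compound 2 (0.94 log units; beyond the scatter). There, a non-aromatic ring gave way to the same aromatic ring, and the half-life fell by a clear margin. Reversing that kind of change should therefore lengthen the half-life, though the entering group is not the one in compound 1.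

The step expected is a 3.5-fold higher number from compound 2 to compound 3 (0.55 log units; beyond the scatter). For compound 3 the estimated half-life is 400 h, with an expected range of 120 h to 1300 h.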

Compound 3, half-life: > 37 h
Compound 3: only a limit was reported; the forecaster's own chance of this, stated with the estimate: 25%; the middle value lies beyond the limit too.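

Compound 3 gives > 37 h, which is a limit and not a number. The steps to compound 3 from compound 1 and from compound 2 cannot be read. The compounds shown leave open the true half-life of compound 3, and whether its non-aromatic ring gives a longer or shorter half-life than the 4H-1,2,4-triazol-4-yl of compound 2.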